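Bromo for chloro: expecting compound 4 from compound 3

The compounds below may be only part of what the source reports. "The series", "measured", "known", "first", "only" and "open" are said of these compounds alone.

Three compounds built on one shared core were tested in an ADME assay on L02 cells (Homo sapiens) for antiproliferative activity, read by MTT assay, with a stated time of 48 h; on this read-out lower numbers stand for stronger inhibition and higher numbers for weaker inhibition. For compound 1 `Cc1cccc(-n2nncc2CN2C(=O)C3(C(C#N)=C(N)Oc4c3c3nc5ccccc5nc3c3ccccc43)c3ccccc32)c1` the result is a limit of the assay, > 50000 nM. Compound 2 `N#CC1=C(N)Oc2c(c3nc4ccccc4nc3c3ccccc23)C12C(=O)N(Cc1cnnn1-c1ccccc1Cl)c1ccccc12` likewise reaches only a limit, > 50000 nM. Going by the values given here, compound 3 `N#CC1=C(N)Oc2c(c3nc4ccccc4nc3c3ccccc23)C12C(=O)N(Cc1cnnn1-c1cccc(Cl)c1)c1ccccc12` gives 35200 nM, the only actual number in the set. The other two results sit at the limit of > 50000 nM in this assay, at which 2 of the 3 values shown sit. The step from compound 1 to compound 3 is an at least 1.4-fold lower number from compound 1 to compound 3 (0.15 log units; that floor lies within the scatter), and the step from compound 2 to compound 3 is an at least 1.4-fold lower number from compound 2 to compound 3 (0.15 log units; that floor lies within the scatter), while the step from compound 1 to compound 2 is a step that the two limits leave unreadable from compound 1 to compound 2. Compound 4 `N#CC1=C(N)Oc2c(c3nc4ccccc4nc3c3ccccc23)C12C(=O)N(Cc1cnnn1-c1cccc(Br)c1)c1ccccc12` has not been measured. It differs from compound 3 by bromo in place of chloro on an aromatic carbon. Among the compounds with values here, no measured step swaps one halogen for another, and the two steps that end at compound 3 only set floors that lie within the scatter, so in this assay no step beyond the scatter is expected. Compound 4 is therefore estimated at 35000 nM, with a range from 15000 nM to 80000 nM. That estimate means an expected step of a 1.0-fold lower number from compound 3 to compound 4 (0.00 log units; within the scatter).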

Compound 4, half-maximal inhibitory concentration: > 50000 nM
Compound 4: a limit, no number; the forecaster's own chance of this, stated with the estimate: 35%; middle value at least 1.4-fold (0.15 log units) away from the limit.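

Bromo in place of chloro is the first swap of one halogen for another in this set, and in this assay it reads as an at least 1.4-fold higher number from compound 3 to compound 4 (0.15 log units; that floor lies within the scatter). So 3-bromophenyl brings no lower number than 3-chlorophenyl, yet the printed floor leaves open that the two differ by no more than ordinary scatter. The steps from compound 1 and from compound 2 to compound 4 cannot be read, and compound 3 remains the only compound with an actual number, while compound 1, compound 2 and compound 4 sit at a limit: the limit of > 50000 nM in this assay, at which 3 of the 4 values shown sit.

As far as these compounds go, it remains open how far above that limit compound 4 truly lies, and so how large the halogen step really is. Also open, from the compounds shown here alone, is how a fluoro, a methoxy or an amine at this place on the aromatic ring would read.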